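Replacing the bromo of compound 1 with hydrogen

A few compounds are considered here, and "the series" means these few. Any claim that something is new, unique, unknown or untested is made for them only; others in the source may bear on it.

In an ADME assay on HEK293 cells (Homo sapiens) for cytotoxicity, read by reporter gene assay and resazurin assay, with a stated time of 48 h (on this read-out lower numbers stand for higher toxicity in this test and higher numbers for lower toxicity in this test), compound 1 `O=C(Nc1ccc(Sc2nc3ccccc3s2)c(Cl)c1)c1cccc(Br)c1` gives > 100000 nM as its read-out, which is a limit of the assay and not a number. Compound 3 `O=C(Nc1ccc(Sc2nc3ccccc3s2)cc1)c1cccc(Br)c1` gives 74000 nM in this assay and compound 2 `O=C(Nc1cccc(Cl)c1)c1cccc(Br)c1O` gives 32000 nM there. Compound 4 `O=C(Nc1ccc(Sc2nc3ccccc3s2)c(Cl)c1)c1ccccc1` carries hydrogen in place of bromo on an aromatic carbon and so turns 3-bromophenyl to phenyl. Going by the values given here, the one measured step available, an at least 1.3-fold lower number from compound 1 to compound 3 (0.13 log units; that floor lies within the scatter) for hydrogen in place of chloro on an aromatic carbon, bears only indirectly, and no measured step removes the bromo. No step beyond the scatter is expected in this assay here, and the estimated change is an at least 1.2-fold lower number from compound 1 to compound 4 (0.09 log units; that floor lies within the scatter) as a working figure. For compound 4 the estimate is 80000 nM with an expected range from 35000 nM to 170000 nM in this series.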

Compound 4, half-maximal cytotoxic concentration: 90000 nM
Compound 4: middle estimate off by 1.1-fold (0.05 log units), on the low side; the measured number falls inside the stated range.
By their numbers in this assay, from the lowest: compound 2; then compounds 3 and 4 (each within the scatter of the next). At a limit, above all of these: compound 1.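

In this assay, hydrogen in place of bromo on an aromatic carbon gives an at least 1.1-fold lower number from compound 1 to compound 4 (0.04 log units; that floor lies within the scatter), the first step read at this position, and it shows no change beyond the scatter on loss of the bromo. The true size of this step stays unknown because compound 1 is a limit and not a number: the limit of > 100000 nM in this assay, at which 1 of the 4 values shown sits.

Open, as far as these compounds go, is whether an amine or a carboxylic acid in place of the bromo would move the read-out. Also open, from the compounds shown here alone, is whether losing the bromo from compound 3, which lacks the chloro, gives a similar step.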